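Swapping a Hexyl Chain for Fluorine on Compound 3

The source may report more compounds than this note shows. Statements on the series, on what has been measured and on what is new or still open speak of the compounds shown alone.

Measured so far:
compound 1, `Cc1coc(-c2nn(Cc3ccccc3F)c3ncccc23)n1`, gives 1200 nM
compound 2, `CCc1c[nH]c(-c2nn(Cc3ccccc3F)c3ncccc23)n1`, gives 600 nM
compound 3, `CCCCCCc1cnc(-c2nn(Cc3ccccc3F)c3ncccc23)nc1N`, gives 1040000 nM

In a functional assay (aorta) with Oryctolagus cuniculus as the target (a lower number here means a stronger inhibitor, a higher number a weaker inhibitor), compound 3 stands at the highest number of the three. Its nearest neighbour is compound 1, and even that gap is far beyond the scatter; compound 2 lies further still. Within the data shown here, the one measured step, a 2.0-fold lower number from compound 1 to compound 2 (0.30 log units; within the scatter), concerns a different ring from the one changed here and tells nothing about a substituent on the ring carried by compound 3.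

Compound 4, `Nc1nc(-c2nn(Cc3ccccc3F)c3ncccc23)ncc1F`, differs from compound 3 by fluoro in place of hexyl on an aromatic carbon. Among the measured compounds shown here, no measured pair shows this change, so the expectation rests only on where compound 3 stands. Because compound 3 gives 1040000 nM, the starting point is very weak, and a move toward the numbers of compound 1 and compound 2 is plausible but unproven. Compound 4 is therefore expected at 80000 nM, in a range from 5000 nM to 1000000 nM, which means an expected step of a 13-fold lower number from compound 3 to compound 4 (1.11 log units; beyond the scatter).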

Compound 4, half-maximal inhibitory concentration: 478000 nM
For compound 4 the middle estimate is 6.0-fold (0.78 log units) below the measured one, and the stated range covers the measured number.
By their numbers in this assay, from the lowest: compounds 2 and 1 (each within the scatter of the next); then compound 4; then compound 3.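

In this assay, the position ortho to the amino group moves only a little when a long chain gives way to a single atom: fluoro in place of hexyl gives a 2.2-fold lower number from compound 3 to compound 4 (0.34 log units; beyond the scatter) as a modest step. The hexyl chain therefore accounts for little of the distance to the other compounds, since the 4-amino-5-fluoropyrimidin-2-yl group still stands apart, with an 800-fold higher number from compound 2 to compound 4 (2.90 log units; beyond the scatter) and a 400-fold higher number from compound 1 to compound 4 (2.60 log units; beyond the scatter) both large steps. Nothing available explains these differences.

The compounds shown leave open how hydrogen, chloro, a methyl group or an ethyl chain at this position would compare with fluoro and hexyl. They also leave open what the 4-amino-5-fluoropyrimidin-2-yl group would give with a hydroxyl group or a methoxy group in place of its amino group.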